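The source may hold more compounds than are shown below. What is called first, only, known or untested is meant among the compounds shown, and "the series" means these compounds.

In a functional assay on HL-60 cells (Homo sapiens) for inhibition, read by MTT assay, with a stated time of 72 h (on this read-out lower numbers stand for stronger inhibition and higher numbers for weaker inhibition), compound 2 `Cc1nc(-c2ccccc2)c(C(=O)N2CCN(c3cccc(C(N)=O)c3)CC2)o1` gives 71 nM. Of the three measured compounds it is the only one whose result is a plain number, so it stands alone as the anchor for any comparison. Compound 1 `CCc1nc(-c2ccc(OC)cc2)c(C(=O)N2CCN(c3cccc(Cl)c3)CC2)o1` reaches only a limit of the assay, > 1000 nM, which is not a number; this is the limit of > 1000 nM in this assay, at which 1 of the 3 values shown sits. Compound 3 `O=C(c1oc(C(F)(F)F)nc1-c1ccccc1F)N1CCN(c2cccc(Cl)c2)CC1` is reported in this assay as "not active" (no number reported), with no number given. Among the measured compounds shown here, no two of the measured compounds differ in a single place, so no measured step is available to guide the size of a change.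

Compound 4 `COc1cccc(N2CCN(C(=O)c3oc(C)nc3-c3ccccc3)CC2)c1` differs from compound 2 in one place: methoxy in place of carbamoyl on an aromatic carbon. The carbamoyl leaves and a methoxy enters on the same aromatic carbon; read one bond further out, a 3-carbamoylphenyl becomes a 3-methoxyphenyl.

For the measured compounds named here, compound 1, the one other compound that carries a methoxy on an aromatic ring, shows only a limit in this assay. The step of a 4.2-fold higher number from compound 2 to compound 4 (0.63 log units; beyond the scatter) is therefore expected to be a loss that goes beyond the usual scatter, although the bare data cannot fix its size. Compound 4 is expected to give 300 nM, with a range from 60 nM to 2000 nM.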

Compound 4, half-maximal inhibitory concentration: 34.8 nM
Compound 4: the middle estimate sits 8.6-fold (0.94 log units) above what was measured; the whole stated range lies above it.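

In this assay, among the compounds shown here, replacing the carbamoyl with a methoxy on this aromatic carbon, meta to a large group, gives a 2.0-fold lower number from compound 2 to compound 4 (0.31 log units; beyond the scatter), the first measured step. For this pair, the carbamoyl and its hydrogen-bond donor are therefore not needed for a low number: the 3-methoxyphenyl has no hydrogen-bond donor, yet it sits on the lower side of a modest step that lies beyond the scatter. For the compounds shown here, nothing measured here accounts for the step, which so far describes only this one pair and this one place on the shared core.

Going by these compounds, whether the same aromatic carbon would take an amine, a carboxylic acid or a longer chain such as ethoxy stays open, as does whether the step from 3-carbamoylphenyl to 3-methoxyphenyl would hold on a core with different groups elsewhere. Compound 1 and compound 3 cannot answer this, since each differs from compound 4 in more than one place and neither has a plain number in this assay.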